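The source may report more compounds than this note shows. Statements on the series, on what has been measured and on what is new or still open speak of the compounds shown alone.

Compound 1 `C=CCCCCCCCC#CC#CCO` gave 5.26 ug/mL in a functional assay on XF498 cells (Homo sapiens) for cytotoxicity; on this read-out lower numbers stand for an effect already at smaller amounts and higher numbers for an effect only at larger amounts of compound.
Compound 2 `C=CCCCCCCCC#CC#CCOCC(=O)O` gave 4.96 ug/mL in this assay.

On these two numbers compound 2 stands lowest, with compound 1 nearest: a 1.1-fold lower number from compound 1 to compound 2 (0.03 log units; within the scatter). Compound 3 `C=CCCCCCCCC#CC#CCOCC(=O)OC` differs from compound 2 by methyl in place of hydrogen on an oxygen next to a carbonyl group, that is, carboxy becomes methoxycarbonyl. Within the data shown here, no measured step covers this change; the only step known, a 1.1-fold lower number from compound 1 to compound 2 (0.03 log units; within the scatter), concerns a different part of the molecule and itself stayed within the scatter. With nothing pointing either way, no step beyond the scatter is expected, a 1.0-fold higher number from compound 2 to compound 3 (0.00 log units; within the scatter). Compound 3 is therefore estimated at 5 ug/mL, expected between 2.5 ug/mL and 10 ug/mL.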

Compound 3, concentration for half-maximal effect: > 30 ug/mL
Compound 3: no number, only a limit (the forecaster's own chance of this, stated with the estimate: 5%); at least 6.0-fold (0.77 log units) between middle value and limit.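

The oxygen-bearing end of the chain proved sensitive to this change, although the earlier carboxymethyl replacement had stayed within the scatter, with a 1.1-fold lower number from compound 1 to compound 2 (0.03 log units; within the scatter). Methyl in place of hydrogen on an oxygen next to a carbonyl group gave an at least 6.0-fold higher number from compound 2 to compound 3 (0.78 log units; beyond the scatter), and the two changes taken together gave an at least 5.7-fold higher number from compound 1 to compound 3 (0.75 log units; beyond the scatter). The result for compound 3 is a limit of the assay, not a number: the limit of > 30 ug/mL in this assay, at which 1 of the 3 values shown sits.

As far as these compounds go, the true size of both steps therefore remains open. Also open, from the compounds shown here alone, is whether an amide or an ethyl ester at this end would give a number like that of compound 2 or like the limit of compound 3.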